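Cyclopentyl replaces (thiophen-2-yl)methyl: does the limit still hold?

This account rests on a few compounds, and the source may have more. Where it says the series, first, only, none or still open, it means among the compounds named here.

Compound 1 `CC(C)(C)c1cc(NC(=O)c2c(Cl)cc(N)cc2Cl)ccc1O` and compound 2 `CC(C)(C)c1cc(NC(=O)c2c(Cl)cc(NCc3cccs3)cc2Cl)ccc1O` share one core and differ only in what sits on a nitrogen on an aromatic ring. In an ADME assay on a cell-free system (serum) for metabolic stability (a lower number here means that the compound disappears faster, a higher number that the compound lasts longer), compound 1 gives > 1 h, which is a limit and not a number. In this assay compound 2 gives > 1 h, and this too is a limit. Compound 2 therefore has no exact half-life, and the two compounds together stand at the limit of > 1 h in this assay, at which 2 of the 2 values shown sit.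

Compound 3 `CC(C)(C)c1cc(NC(=O)c2c(Cl)cc(NC3CCCC3)cc2Cl)ccc1O` changes the same place, with cyclopentyl in place of (thiophen-2-yl)methyl on that nitrogen: cyclopentyl in place of (thiophen-2-yl)methyl on a nitrogen on an aromatic ring.

Going by the values given here, the one measured step at this nitrogen is a step that the two limits leave unreadable from compound 1 to compound 2, so it offers no size to carry over. No step beyond the usual scatter is expected in this assay, in either direction. The expected change is a step that the limit leaves unreadable from compound 2 to compound 3, an estimate that rests on very little. Compound 3 is estimated at 1.5 h, within an expected range of 0.7 h to 4 h, and the assay may well report only a limit again.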

Compound 3, half-life: > 1 h
Compound 3 gave a limit, no number; the forecaster's own chance of this, stated with the estimate: 75%; the middle value is on the limit's open side.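

In this assay compound 3 gives > 1 h and this is a limit, not a number. No step among compound 1, compound 2 and compound 3 can be read, because each result is only a limit: the limit of > 1 h in this assay, at which 3 of the 3 values shown sit.

The compounds shown leave open the actual half-life of each compound and whether the groups on this nitrogen make any difference.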